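Adding a chloro group to the anilino ring of compound 1

The compounds below may be only part of what the source reports. "The series", "measured", "known", "first", "only" and "open" are said of these compounds alone.

Compounds measured in an ADME assay on BHK-21 cells (Mesocricetus auratus) for cytotoxicity, with a stated time of 3 days; a lower number here means that less compound is tolerated, a higher number that more compound is tolerated:
compound 1, `CC(Sc1nnc(-c2ccncc2)s1)C(=O)Nc1ccccc1`: > 50000 nM, a limit of the assay, not a number
compound 2, `O=C(CCSc1nnc(-c2ccncc2)s1)Nc1ccccc1`: > 50000 nM, a limit of the assay
compound 3, `O=C(CCSc1nnc(-c2ccncc2)s1)Nc1ccc(Cl)cc1Cl`: > 50000 nM, a limit of the assay

Compound 1 thus stands only at a limit in this assay, and the two further values shown are limits as well, which is the limit of > 50000 nM in this assay, at which 3 of the 3 values shown sit. Going by the values given here, the single step between measured compounds, a step that the two limits leave unreadable from compound 2 to compound 3, is left unreadable by the two limits, so no measured step gives a readable size for any change on the amide-type nitrogen.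

Compound 4, `CC(Sc1nnc(-c2ccncc2)s1)C(=O)Nc1ccc(Cl)cc1`, differs from compound 1 in one place: chloro in place of hydrogen on an aromatic carbon. With every value shown sitting at the same limit, compound 4 is expected to show no step beyond the scatter and to sit at that limit too. Compound 4 is therefore estimated at 50000 nM, within 25000 nM to 100000 nM, an expected step of a number no higher from compound 1 to compound 4 (the limit leaves the size open).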

Compound 4, half-maximal cytotoxic concentration: > 50000 nM
Compound 4: a limit, no number (the forecaster's own chance of this, stated with the estimate: 85%); the middle value sits exactly at the limit.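

No step can be read from compound 1 to compound 4, as both stand only at a limit in this assay: the limit of > 50000 nM in this assay, at which 4 of the 4 values shown sit.

The compounds shown leave open where any of them would actually reach half-maximal cytotoxicity, and so whether the chloro group changes it at all.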